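Diethylamino in place of dimethylamino on compound 3

The source may hold more compounds than are shown below. What is called first, only, known or untested is meant among the compounds shown, and "the series" means these compounds.

Compound 3 `CN(C)CCn1cccc1/C=N/NC(=O)Nc1ccc(Oc2ccnc3[nH]ccc23)cc1` has no number in a functional assay on HepG2 cells (Homo sapiens) for antiproliferative activity, read by MTT assay, with a stated time of 72 h (on this read-out higher numbers stand for weaker inhibition and lower numbers for stronger inhibition), and is recorded as "not active" (no number reported) there. Compound 1 `O=C(N/N=C/c1ccc(Br)cc1)Nc1ccc(Oc2ccnc3[nH]ccc23)cc1` reaches 1000 nM and compound 2 `COc1ccc(/C=N/NC(=O)Nc2ccc(Oc3ccnc4[nH]ccc34)cc2)cc1` reaches 9740 nM with methoxy in place of bromo on an aromatic carbon. For the measured compounds named here, the only measured step is a 9.7-fold higher number from compound 1 to compound 2 (0.99 log units; beyond the scatter) and it concerns a different place, so it gives no size for the change at hand. Compound 4 `CCN(CC)CCn1cccc1/C=N/NC(=O)Nc1ccc(Oc2ccnc3[nH]ccc23)cc1` differs from compound 3 by diethylamino in place of dimethylamino on a saturated chain carbon, two bonds along the chain from an aromatic nitrogen with diethylamino in place of dimethylamino on a saturated chain carbon, two bonds along the chain from an aromatic nitrogen. Going by the values given here, because compound 3 is recorded as "not active" (no number reported) no step can be sized, and only weak inhibition is expected. Compound 4 is estimated at 20000 nM with an expected range from 5000 nM to 80000 nM if a number is reported at all.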

Compound 4, half-maximal inhibitory concentration: 5880 nM
Beside the measured number, compound 4's estimate is 3.4-fold (0.53 log units) above it; measured number inside the range.
By their numbers in this assay, from the lowest: compound 1; then compounds 4 and 2 (each within the scatter of the next).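

For the compounds shown here, compound 3 carries no number and compound 4 carries one, so no step between them can be read. The size of the change from dimethylamino to diethylamino stays open, and no evidence shown bears on this result.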